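Changing the aryl group on the ring nitrogen of compound 2

This account rests on a few compounds, and the source may have more. Where it says the series, first, only, none or still open, it means among the compounds named here.

Compound 1 `CCNC(=O)c1cc(Oc2ccc(NC(=O)c3cc4cccnc4n(-c4ccc(Cl)cc4)c3=O)cc2)ccn1`: 250 nM
Compound 2 `CCNC(=O)c1cc(Oc2ccc(NC(=O)c3cc4cccnc4n(-c4ccc(Br)cc4F)c3=O)cc2)ccn1`: 1820 nM

Both compounds were tested in a functional assay on A549 cells (Homo sapiens) for antiproliferative activity, read by MTT assay, with a stated time of 72 h; on this read-out lower numbers stand for stronger inhibition and higher numbers for weaker inhibition. Going by the values given here, of the two numbers, compound 2 stands at the higher, weaker end: the single measured step, a 7.3-fold higher number from compound 1 to compound 2 (0.86 log units; beyond the scatter), shows that exchanging 4-chlorophenyl for 4-bromo-2-fluorophenyl on the aromatic nitrogen clearly weakened inhibition. Compound 3 `CCNC(=O)c1cc(Oc2ccc(NC(=O)c3cc4cccnc4n(-c4ccc(C(F)(F)F)cc4Cl)c3=O)cc2)ccn1` has not yet been measured. It differs from compound 2 in one place: 2-chloro-4-(trifluoromethyl)phenyl in place of 4-bromo-2-fluorophenyl on an aromatic nitrogen. Both the group that leaves and the group that enters are halogenated phenyl rings carrying a small group and a larger group. Among the compounds with values here, the only step that bears on this position, a 7.3-fold higher number from compound 1 to compound 2 (0.86 log units; beyond the scatter), involved a different pair of groups, so it shows that a swap at this site can move the number beyond the scatter but gives no direction for this particular exchange. The step of a 1.2-fold lower number from compound 2 to compound 3 (0.08 log units; within the scatter) is therefore expected to be small, in either direction, with wide uncertainty. Compound 3 is estimated at 1500 nM in this assay, within a range from 400 nM to 6000 nM.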

Compound 3, half-maximal inhibitory concentration: 3290 nM
Compound 3: middle estimate off by 2.2-fold (0.34 log units), on the low side; measured number inside the range.
By their numbers in this assay, from the lowest: compound 1; then compounds 2 and 3 (each within the scatter of the next).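

In this assay, replacing 4-bromo-2-fluorophenyl with 2-chloro-4-(trifluoromethyl)phenyl gives a 1.8-fold higher number from compound 2 to compound 3 (0.26 log units; within the scatter), so this exchange leaves the two compounds indistinguishable, even though the two rings carry different halogens and the entering ring holds a trifluoromethyl group instead of a bromine. The comparison with the 4-chlorophenyl ring gives a 13-fold higher number from compound 1 to compound 3 (1.12 log units; beyond the scatter), which joins a 7.3-fold higher number from compound 1 to compound 2 (0.86 log units; beyond the scatter) to show that, among these three compounds, both rings with two substituents give clearly weaker inhibition than the ring with one, and none of the three goes against this. No measurement shown here explains why the numbers fall this way.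

Each of these two steps from compound 1 changes the ring in more than one way, so the compounds shown leave open whether the halogen in the 2-position of the ring, the group in its 4-position, or the two together account for the weaker inhibition. They also leave open how the number would respond to a plain phenyl ring, to 2-fluorophenyl, or to a ring carrying an oxygen or nitrogen group, such as 4-methoxyphenyl or 4-aminophenyl.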